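The source may report more compounds than this note shows. Statements on the series, on what has been measured and on what is new or still open speak of the compounds shown alone.

Measured compounds:
compound 1 `O=C(Nc1ccc(C(F)(F)F)cc1)NC1CCN(C(=O)C2=COCC2)CC1` gives 2.3 ug/mL in a physicochemical assay for solubility, read by mass spectrometry, in phosphate buffer, with a stated time of 24 h, at pH 7.4; a higher number here means a more soluble compound, a lower number a less soluble compound
compound 2 `CCOC(=O)N1CCC(NC(=O)Nc2ccc(OC(F)(F)F)c(F)c2)CC1` gives 0.35 ug/mL
compound 3 `CC[C@H](C)C(=O)N1CCC(NC(=O)Nc2ccc(OC(F)(F)F)c(OC(F)(F)F)c2)CC1` gives 5.5 ug/mL

Among these three numbers compound 1 stands second highest. Its nearest neighbour is compound 3, whose higher number lies beyond the usual scatter, and the furthest is compound 2, whose lower number lies well beyond it. Compound 4 `O=C(Nc1ccc(C(F)(F)F)cc1)NC1CCN(C(=O)c2ccoc2)CC1` is not yet measured. It differs from compound 1 in one place: a group of 5 heavy atoms (4 carbon, 1 oxygen; one five-membered aromatic ring with 1 hetero atom) in place of a group of 5 heavy atoms (4 carbon, 1 oxygen; one five-membered non-aromatic ring with 1 hetero atom), on a carbonyl carbon. Going by the values given here, no comparable step between measured compounds exists in this set, so the size of the change can only be guessed. A small shift downward, within the scatter, is expected, giving a step of a 1.3-fold lower number from compound 1 to compound 4 (0.11 log units; within the scatter). Compound 4 is therefore estimated at 1.8 ug/mL, with a range from 0.6 ug/mL to 5 ug/mL.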

Compound 4, solubility: 2.2 ug/mL
For compound 4 the middle estimate is 1.2-fold (0.09 log units) below the measured one; the range from low to high includes it.
By their numbers in this assay, from the lowest: compound 2; then compounds 4 and 1 (each within the scatter of the next); then compound 3.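

Going by these compounds alone, replacing the non-aromatic five-membered ring on the carbonyl carbon with furan-3-yl provides the first comparison in this set of compounds that differ in one place. In this assay, the step reads a 1.0-fold lower number from compound 1 to compound 4 (0.02 log units; within the scatter), so this exchange of two rings of equal heavy-atom count leaves the two compounds indistinguishable. As far as these compounds go, whether an open-chain group, a piperidine bearing an amine or a carboxylic acid at this carbonyl carbon would give a different number remains open. The data offer no measured explanation for the match between these two rings.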